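Carboxylic acid linker change on the pyrazolylmethyl series

The compounds below may be only part of what the source reports. "The series", "measured", "known", "first", "only" and "open" are said of these compounds alone.

Measured so far:
compound 1, `O=C(O)/C=C/c1ccc(COc2ccccc2)cc1OCCc1ccc2ccccc2c1`: 140 nM
compound 2, `O=C(O)C#Cc1ccc(Cn2cccn2)cc1OCCc1ccc2ccccc2c1`: 1200 nM

Two compounds have been run in an in vitro functional assay on CHO cells for antagonist activity at prostaglandin E2 receptor EP3 subtype (Mus musculus); on this read-out higher numbers stand for weaker inhibition and lower numbers for stronger inhibition. Compound 1 gives 140 nM in this assay, and compound 2 gives 1200 nM; compound 2 holds the higher of the two numbers, and the gap to compound 1 lies beyond the scatter. The two compounds differ in more than one place, so nothing about either change alone can be read from this pair.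

Compound 3, `O=C(O)CCCc1ccc(Cn2cccn2)cc1OCCc1ccc2ccccc2c1`, is the next compound, not yet measured. It differs from compound 2 in one place: 3-carboxypropyl in place of 2-carboxyethynyl on an aromatic carbon. Among the measured compounds shown here, no measured pair isolates this kind of change on the acid side chain, so the direction of the step is not fixed by the data; a step of modest size in either direction, or none beyond the scatter, would fit what is known. The working expectation for compound 3 in this assay is a step of a 1.3-fold higher number from compound 2 to compound 3 (0.10 log units; within the scatter), with compound 3 estimated at 1500 nM, within a range from 400 nM to 6000 nM.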

Compound 3, half-maximal inhibitory concentration: 460 nM
The estimate for compound 3 lay 3.3-fold (0.51 log units) above the measured number; low and high end bracket the measured number.
By their numbers in this assay, from the lowest: compound 1; then compound 3; then compound 2.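

In this assay, among the compounds shown here, the first single-place step falls on the acid side chain, on the aromatic carbon para to the (1H-pyrazol-1-yl)methyl group, and this position responds to change: 3-carboxypropyl in place of 2-carboxyethynyl gives a 2.6-fold lower number from compound 2 to compound 3 (0.42 log units; beyond the scatter). With the (1H-pyrazol-1-yl)methyl group held fixed, the triple bond of the side chain is therefore not needed to retain inhibition, and the saturated chain of 6 heavy atoms gives the lower number while keeping the carboxylic acid. No measurement shown here gives a reason for the step.

Triple bond and chain length change together in this one step, so their separate contributions cannot be read, and a 2-carboxyethyl or 4-carboxybutyl chain would help to tell them apart. For the compounds shown here, whether the position needs the carboxylic acid itself remains open, as a tetrazole or a primary amide at the end of the chain would show, and the part played by the 2-carboxyvinyl chain of compound 1 cannot be read because no single-place pair links it to the pyrazolylmethyl compounds.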